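This account rests on a few compounds, and the source may have more. Where it says the series, first, only, none or still open, it means among the compounds named here.

The compounds measured in a functional assay for inhibition, with Homo sapiens as the target (on this read-out lower numbers stand for stronger inhibition and higher numbers for weaker inhibition), are:
compound 1 `CCOC(=O)c1cccc(Nc2nccc(-c3ccccn3)n2)c1` with 3000 nM
compound 2 `CCOC(=O)c1cccc(Nc2nccc(-c3cccnc3)n2)c1` with 10500 nM
compound 3 `CNc1ccc(Nc2nccc(-c3ccccn3)n2)cc1` with 1400 nM

Compound 1 and compound 2 share a core and differ in one place: pyridin-3-yl in place of pyridin-2-yl on an aromatic carbon. That change gave a 3.5-fold higher number from compound 1 to compound 2 (0.54 log units; beyond the scatter). Compound 3 sits on another core; the difference between the core of compound 3 and the core of compound 1 is not broken down here. Among the three measured compounds, compound 3 gives the lowest number, and its steps to compound 1 and to compound 2 both lie beyond the scatter, so compound 3 is the most potent of the three.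

Compound 4 `CNc1ccc(Nc2nccc(-c3cccnc3)n2)cc1` has not yet been measured in this assay. It stands to compound 3 as compound 2 stands to compound 1: pyridin-3-yl in place of pyridin-2-yl on an aromatic carbon. The surroundings of the changed carbon are described almost alike for the two pairs, yet not word for word: for compound 1 to compound 2 the carbon is meta to a large group, for compound 3 to compound 4 it is meta to a group of 9 heavy atoms, so the two changes are the same kind of change rather than the same change. A single measured pair is the whole precedent.

Compound 4 is expected to give about 4900 nM in this assay, with a likely range from 2500 nM to 10000 nM. Going by the values given here, for compound 4 the expected step is a 3.5-fold higher number from compound 3 to compound 4 (0.54 log units; beyond the scatter), set to match the earlier one because a 3.5-fold higher number from compound 1 to compound 2 (0.54 log units; beyond the scatter) is the only guide to this kind of change here.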

Compound 4, half-maximal inhibitory concentration: 2100 nM
The estimate for compound 4 lay 2.3-fold (0.37 log units) above the measured number; the measured number lies below the stated range.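

In this assay, putting pyridin-3-yl in place of pyridin-2-yl on the core of compound 3 gave a 1.5-fold higher number from compound 3 to compound 4 (0.18 log units; within the scatter), a step too small to separate compound 3 from compound 4. Set beside the same change on the core of compound 1, the two steps cannot be told apart: the same change on two cores in this assay, a 3.5-fold higher number (0.54 log units; beyond the scatter) from compound 1 to compound 2 and a 1.5-fold higher number (0.18 log units; within the scatter) from compound 3 to compound 4, 2.3-fold (0.37 log units) apart, within the scatter of two such steps. This shows that the two cores give no sign of responding differently to this change, but it does not show that the change has the same size on both, nor that it carries a reliable penalty on the core of compound 3, and with a single pair on each core a real but modest difference between the cores cannot be excluded.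

The compounds shown leave open how the series would respond on this same carbon to pyridin-4-yl or a plain phenyl ring, neither of which appears among them. They also leave open whether the agreement between the two steps would hold on a third core, for instance one bearing a carboxylic acid or a longer amine chain on its aniline ring.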